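The compounds below may be only part of what the source reports. "The series", "measured", "known", "first", "only" and "open" are said of these compounds alone.

Measured compounds:
Compound 1, `COc1cc(N)c(Cl)cc1C(=O)CCC1CCN(CC2CCCCCC2)CC1`, gives 3.9 nM in an assay on membranes from brain for displacement of a labelled ligand from 5-hydroxytryptamine receptor 4 (Cavia porcellus), read by radioligand binding, with a stated time of 30 min; on this read-out higher numbers stand for weaker inhibition and lower numbers for stronger inhibition.
Compound 2, `COc1cc(N)c(Cl)cc1C(=O)CCC1CCN(CC2CCCCC2C)CC1`, gives 4.9 nM in this assay.

On these two numbers compound 2 holds the higher one, but the step of a 1.3-fold higher number from compound 1 to compound 2 (0.10 log units; within the scatter) lies within the scatter, so the two compounds cannot be told apart in this assay. Compound 3, `COc1cc(N)c(Cl)cc1C(=O)CCC1CCN(Cc2cccnc2)CC1`, has not yet been measured. It differs from compound 2 in one place: pyridin-3-yl in place of 2-methylcyclohexyl on a saturated chain carbon bound to an amine nitrogen in a ring. Going by the values given here, the only measured step, a 1.3-fold higher number from compound 1 to compound 2 (0.10 log units; within the scatter), exchanges one saturated carbon ring for another and says nothing about putting an aromatic ring with one nitrogen in the same place; no measured pair bears directly on this change. Among the compounds with values here, the exchange of 2-methylcyclohexyl for pyridin-3-yl is therefore an open question in this assay, and with no step to rest on, a step of modest size toward a higher number is expected, a 6.1-fold higher number from compound 2 to compound 3 (0.79 log units; beyond the scatter), with a wide range that also covers no change beyond the scatter. Compound 3 is thus estimated at 30 nM, between 6 nM and 150 nM.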

Compound 3, inhibition constant: 20.4 nM
Compound 3: middle estimate off by 1.5-fold (0.17 log units), on the high side; low and high end bracket the measured number.
By their numbers in this assay, from the lowest: compounds 1 and 2 (each within the scatter of the next); then compound 3.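

Going by these compounds alone, compound 1 and compound 2 showed only that one saturated carbon ring gives way to another on a saturated chain carbon bound to an amine nitrogen in a ring without a change that can be read in this assay. Pyridin-3-yl brings the first readable change at this position, a 4.2-fold higher number from compound 2 to compound 3 (0.62 log units; beyond the scatter), and the comparison with cycloheptyl points the same way, a 5.2-fold higher number from compound 1 to compound 3 (0.72 log units; beyond the scatter), so the position does respond to an aromatic ring with one hetero atom, though both steps are modest and compound 3 still gives 20.4 nM. The compounds shown offer no independent measurement that would account for this change.

The exchange replaces a saturated carbon ring with an aromatic ring and adds a ring nitrogen in a single step, so these compounds cannot say which of the two goes with the higher number, a question that a phenyl group in the same place would address. On these data alone, whether the position of the ring nitrogen matters also remains open, and pyridin-4-yl or pyridin-2-yl would bear on that.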